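A 4-fluorophenyl group replaces ethyl on compound 2

The source may report more compounds than this note shows. Statements on the series, on what has been measured and on what is new or still open speak of the compounds shown alone.

In an ADME assay on J774 cells (Mus musculus) for cytotoxicity (a lower number here means that less compound is needed, a higher number that more compound is needed for the effect), compound 1 `COC(=O)c1c[nH]c2ccc(OCCc3ccccc3)cc2c1=O` gives 2200 nM as a measured number. Compound 2 `CCOc1ccc2[nH]cc(C(=O)OC)c(=O)c2c1` stands at > 20000 nM as a limit of the assay, not a number. Among the compounds with values here, compound 3 `COC(=O)c1c[nH]c2ccc(Oc3ccc(F)cc3)cc2c1=O` has 4-fluorophenyl in place of ethyl on an oxygen on an aromatic ring as its only change. Within the data shown here, one measured step bears on this, an at least 9.0-fold higher number from compound 1 to compound 2 (0.95 log units; beyond the scatter) with hydrogen in place of phenyl, and compound 3 regains an aromatic ring there. A similar move toward a lower number in this assay is therefore expected, namely an at least 4.0-fold lower number from compound 2 to compound 3 (0.60 log units; beyond the scatter) (an estimate). For compound 3 the estimated value is 5000 nM (expected range 1500 nM to 20000 nM).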

Compound 3, half-maximal effective concentration: > 20000 nM
Compound 3 ended at the assay's limit; the forecaster's own chance of this, stated with the estimate: 25%; middle value at least 4.0-fold (0.60 log units) away from the limit.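

In this assay, an aromatic ring on the oxygen does not by itself restore the number seen with phenethyl: 4-fluorophenyl in place of phenethyl gives an at least 9.0-fold higher number from compound 1 to compound 3 (0.95 log units; beyond the scatter). At this position, then, the two aryl-bearing groups are not interchangeable. The step between compound 2 and compound 3 cannot be read, because both stand at a limit of the assay, not at a number: the limit of > 20000 nM in this assay, at which 2 of the 3 values shown sit.

The compounds shown leave open whether the two-carbon chain or the fluorine matters here. A benzyl group or an unsubstituted phenyl on that oxygen would bear on this.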